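This account rests on a few compounds, and the source may have more. Where it says the series, first, only, none or still open, it means among the compounds named here.

Compound 2, `O=C1S/C(=C\c2ccc(O)cc2)C(=O)N1Cc1ccccc1`, gives the lower of the two measured numbers in an ADME assay on cells (Hepatocyte, Homo sapiens) for cytotoxicity, read by MTT assay, with a stated time of 90 min, tested at 100 uM; a higher number here means a weaker effect of the compound at the concentration tested, a lower number a stronger effect: compound 2 gives 40.8%, while compound 1, `Cc1c(C)c2c(c(C)c1CCCCCCN)CCC(C)(COc1ccc(/C=C3\SC(=O)N(C)C3=O)cc1)O2`, gives 82.6%, a gap beyond the usual scatter. Compound 3, `O=C1S/C(=C\c2ccc(O)cc2)C(=O)N1C/C=C/c1ccccc1`, differs from compound 2 in one place: 2-phenylethenyl in place of phenyl on a saturated chain carbon bound to an amide-type nitrogen in a ring. Among the measured compounds shown here, no measured pair shows this change, so nothing here fixes its effect. The 2-phenylethenyl group is expected to shift the read-out only a little, giving an expected step of a number 2.8 percentage points lower from compound 2 to compound 3 (within the scatter), which would likely stay within the scatter. Compound 3 is therefore estimated at 38%, with a range from 15% to 65%.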

Compound 3, a percentage reported as activity, at one concentration (the size of the read-out at that concentration, not a potency): 88.8%
Estimate against measurement, compound 3: 50.8 percentage points below, outside the stated range (above it).
By their numbers in this assay, from the lowest: compound 2; then compounds 1 and 3 (each within the scatter of the next).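

In this assay, 2-phenylethenyl in place of phenyl on a saturated chain carbon bound to an amide-type nitrogen in a ring gives a number 48 percentage points higher from compound 2 to compound 3 (beyond the scatter) and so a much weaker effect at the concentration tested. Among the compounds shown here, this position is therefore sensitive to the group it carries, which the earlier compounds could not show, as they offered no pair differing in one place. Nothing available explains this step.

The compounds shown leave open whether 2-phenylethyl, which lacks the double bond, would read like phenyl or like 2-phenylethenyl. From the compounds shown here alone, how an amine in this place would read also stays open.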